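Oxolan-3-yl to oxan-3-yl on the ether side chain

This account rests on a few compounds, and the source may have more. Where it says the series, first, only, none or still open, it means among the compounds named here.

Measured so far in a functional assay on RS4-11 cells (Homo sapiens) for inhibition, read by CCK-8 assay, with a stated time of 72 h; on this read-out lower numbers stand for stronger inhibition and higher numbers for weaker inhibition:
- compound 1 `CN(C)CCCNc1ccc(S(=O)(=O)NC(=O)c2ccc(N3CCN(CC4=C(c5ccc(C(F)(F)F)cc5)CC(C)(C)CC4)CC3)cc2Oc2cnc3[nH]ccc3c2)cc1[N+](=O)[O-]`: 3.9 nM
- compound 2 `CC1(C)CCC(CN2CCN(c3ccc(C(=O)NS(=O)(=O)c4ccc(OCC5CCOC5)c([N+](=O)[O-])c4)c(Oc4cnc5[nH]ccc5c4)c3)CC2)=C(c2ccc(C(F)(F)F)cc2)C1`: 47 nM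

Of the two measured compounds, compound 2 has the higher number, at 47 nM. The next change leads to compound 3 `CC1(C)CCC(CN2CCN(c3ccc(C(=O)NS(=O)(=O)c4ccc(OCC5CCCOC5)c([N+](=O)[O-])c4)c(Oc4cnc5[nH]ccc5c4)c3)CC2)=C(c2ccc(C(F)(F)F)cc2)C1`: oxan-3-yl in place of oxolan-3-yl on a saturated chain carbon bound to an oxygen on an aromatic ring. In words, this is oxan-3-yl in place of oxolan-3-yl on a saturated chain carbon bound to an oxygen on an aromatic ring. Going by the values given here, the only measured step at this part of the structure is large, a 12-fold higher number from compound 1 to compound 2 (1.08 log units; beyond the scatter), but it replaced (3-(dimethylamino)propyl)amino with (oxolan-3-yl)methoxy, a much wider change than this one. Among the compounds with values here, no measured step tests ring size alone. No step beyond the scatter is therefore expected in this assay, and no direction is favoured. The expected step is a 1.2-fold lower number from compound 2 to compound 3 (0.07 log units; within the scatter). Compound 3 is estimated at 40 nM, with an expected range of 15 nM to 120 nM.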

Compound 3, half-maximal inhibitory concentration: 12 nM
Estimate against measurement, compound 3: 3.3-fold (0.52 log units) above; measured number outside the range, below it.
By their numbers in this assay, from the lowest: compound 1; then compound 3; then compound 2.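

In this assay, ring size alone matters at this position: oxan-3-yl in place of oxolan-3-yl gives a 3.9-fold lower number from compound 2 to compound 3 (0.59 log units; beyond the scatter) and so moves the number beyond the scatter, which the wider change from compound 1 to compound 2 could not show. With the six-membered ring, what separates the ether side chain from (3-(dimethylamino)propyl)amino narrows to a 3.1-fold higher number from compound 1 to compound 3 (0.49 log units; beyond the scatter) in place of a 12-fold higher number from compound 1 to compound 2 (1.08 log units; beyond the scatter) for the five-membered ring, although compound 1 still has the lowest number of the three. Nothing available explains the gain from the larger ring.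

As far as these compounds go, two ring sizes define no trend, so it remains open how a seven-membered oxepanyl ring or the isomeric oxan-4-yl group would behave on the same chain. From the compounds shown here alone, it is also open whether a piperidinyl ring, which carries an amine as compound 1 does, would close the remaining gap to compound 1.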